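Varying the amine-bearing substituent in a series

The source may hold more compounds than are shown below. What is called first, only, known or untested is meant among the compounds shown, and "the series" means these compounds.

Measured so far in an assay on HeLa cells for inhibition of sphingosine-1-phosphate transporter SPNS2 (Mus musculus), read by LC-MS, tested at 2 uM; on this read-out higher numbers stand for more inhibition at the one concentration tested (going by the name of the read-out) and lower numbers for less inhibition:
compound 1 `CCCCCCCCCCc1ccc(-c2noc(C3CNC3)n2)cc1` gives 65%
compound 2 `CCCCCCCCCCc1ccc(-c2noc(CN)n2)cc1` gives 62%
compound 3 `CCCCCCCCCCc1ccc(-c2noc(CCCN(C)C)n2)cc1` gives 8%

Compound 1 and compound 2 lie within the scatter of each other, a number 3 percentage points lower from compound 1 to compound 2 (within the scatter), while compound 3 sits far lower, a number 57 percentage points lower from compound 1 to compound 3 (beyond the scatter) and a number 54 percentage points lower from compound 2 to compound 3 (beyond the scatter). Compound 4 `CCCCCCCCCCc1ccc(-c2noc([C@H]3CCCN3)n2)cc1` is not yet measured; it differs from compound 1 by pyrrolidin-2-yl in place of azetidin-3-yl on an aromatic carbon. Both steps from compound 1 bear on this: exchange for aminomethyl stayed within the scatter, whereas exchange for 3-(dimethylamino)propyl was large. Pyrrolidin-2-yl, like azetidin-3-yl, is a ring with one hetero atom carrying one hydrogen-bond donor and one acceptor, so no step beyond the scatter is expected, a number 5 percentage points lower from compound 1 to compound 4 (within the scatter). Compound 4 is therefore estimated at 60%, within 40% to 78%.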

Compound 4, a percentage reported as inhibition, at one concentration (the size of the read-out at that concentration, not a potency): 12%
Compound 4: the middle estimate sits 48 percentage points above what was measured; measured number outside the range, below it.
By their numbers in this assay, from the lowest: compounds 3 and 4 (each within the scatter of the next); then compounds 2 and 1 (each within the scatter of the next).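

In this assay, a saturated ring with the same donor and acceptor counts does not keep the number at this position: the step is a number 53 percentage points lower from compound 1 to compound 4 (beyond the scatter), and against the open-chain aminomethyl group it is a number 50 percentage points lower from compound 2 to compound 4 (beyond the scatter). With pyrrolidin-2-yl the result is a number 4 percentage points higher from compound 3 to compound 4 (within the scatter), so the low numbers here include both a ring and a chain. No evidence on hand accounts for the change.

From the compounds shown here alone, whether the loss follows ring size, the attachment point or the defined stereocentre remains open. Pyrrolidin-3-yl and the opposite stereoisomer of pyrrolidin-2-yl would help separate these.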